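The source may hold more compounds than are shown below. What is called first, only, known or untested is meant among the compounds shown, and "the series" means these compounds.

Of the compounds shown here, two have so far been measured in an ADME assay on J774 cells (Mus musculus) for cytotoxicity, read by MTT assay, with a stated time of 48 h, tested at 50 ug/mL; on this read-out lower numbers stand for a stronger effect and higher numbers for a weaker effect at the one concentration tested. Compound 1 `O=C(N/N=C/c1ccc(Cl)cc1)c1cnccn1` gives 83%, and compound 2 `O=C(N/N=C/c1cccc(O)c1)c1cnccn1` gives 100%. Of these two, compound 1 has the lower number, which here means the stronger effect on the cells, and compound 2 stands higher by a margin that lies beyond the usual scatter of such readings, so the two results are genuinely different.

The unmeasured compound 3 `CN(C)c1ccc(/C=N/NC(=O)c2cnccn2)cc1` shares the core of compound 1 and differs from it in one place: dimethylamino in place of chloro on an aromatic carbon. The change sits on an aromatic carbon of a six-membered aromatic ring of carbon only, para to a large group. Going by the values given here, no pair of measured compounds shows this kind of exchange, so the size of the step can only be judged loosely. The step is expected to be a number 7 percentage points higher from compound 1 to compound 3 (within the scatter), small and, if anything, upward, not clearly beyond the scatter. Compound 3 is therefore expected to give about 90%, with a likely range from 72% to 105%.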

Compound 3, a percentage reported as activity, at one concentration (the size of the read-out at that concentration, not a potency): 93%
Compound 3: middle estimate off by 3 percentage points, on the low side; measured number inside the range.
By their numbers in this assay, from the lowest: compounds 1, 3 and 2 (each within the scatter of the next, the first and the last beyond it).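

At this place, on an aromatic carbon of a six-membered aromatic ring of carbon only and para to a large group, putting dimethylamino in place of chloro gives a number 10 percentage points higher from compound 1 to compound 3 (within the scatter) in this assay on otherwise unchanged molecules. Going by these compounds alone, this is the first direct reading of a change in one place on the shared core, and it shows that three heavy atoms, including a hydrogen-bond acceptor, can replace a single chlorine without a step that clears the usual scatter of this read-out. The compounds shown offer no independent measurement that could explain this result.

Going by these compounds, whether the step stays this small for other groups at the same place remains open, as only chloro and dimethylamino are compared there, and a carboxylic acid, a primary amine or a longer alkyl chain could give a different answer. One pair also cannot tell whether the same exchange would give a similar step at another carbon of the ring or on a different core.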